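Ester side-chain extension in the cytotoxicity series

This account rests on a few compounds, and the source may have more. Where it says the series, first, only, none or still open, it means among the compounds named here.

For the measured compounds named here, compound 3 `CCC(=O)OCc1c(F)c(N)c2c(=O)cc(-c3ccc(N)c(F)c3)oc2c1F` is the only member of the set with a number in a functional assay on HeLa cells (Homo sapiens) for cytotoxicity, read by neutral red uptake, with a stated time of 3 days; a higher number here means a weaker inhibitor, a lower number a stronger inhibitor: compound 3 gives 69000 nM. Compound 1 `Nc1ccc(-c2cc(=O)c3c(N)c(F)c(Cl)c(F)c3o2)cc1F` reaches only a limit in this assay, > 100000 nM. Compound 2 `CN(C)c1c(F)c(N)c2c(=O)cc(-c3ccc(N)c(F)c3)oc2c1F` likewise reaches only a limit, > 100000 nM. The step of an at least 1.4-fold lower number from compound 1 to compound 3 (0.16 log units; that floor lies within the scatter) and the step of an at least 1.4-fold lower number from compound 2 to compound 3 (0.16 log units; that floor lies within the scatter) are read against (the limit of > 100000 nM in this assay, at which 2 of the 3 values shown sit), and neither floor clears the scatter; the step that the two limits leave unreadable from compound 1 to compound 2 is unreadable.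

Compound 4 `CN(C)CCCC(=O)OCc1c(F)c(N)c2c(=O)cc(-c3ccc(N)c(F)c3)oc2c1F` differs from compound 3 in one place: (dimethylamino)methyl in place of hydrogen on a saturated chain carbon, two bonds along the chain from a carbonyl carbon. The shared core of compound 3 is kept, and propanoyl becomes (3-(dimethylamino)propyl)carbonyl. Going by the values given here, none of the measured steps touches this chain: all three move the substituent on the aromatic carbon, and none of them yields a size that clears the scatter. No step beyond the scatter is therefore expected in this assay, in either direction. The step of a 1.0-fold higher number from compound 3 to compound 4 (0.01 log units; within the scatter) is estimated as no change beyond the scatter. Compound 4 is expected at 70000 nM, with a range from 30000 nM to 160000 nM, and with a fair chance that this assay again returns only a limit.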

Compound 4, half-maximal inhibitory concentration: 4500 nM
The estimate for compound 4 lay 16-fold (1.19 log units) above the measured number, outside the stated range (below it).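

For the compounds shown here, the step of a 15-fold lower number from compound 3 to compound 4 (1.19 log units; beyond the scatter) is the first in this assay to clear the scatter, and it falls on the ester side chain with the shared core kept. Going by these compounds alone, the earlier steps all moved the substituent on the aromatic carbon and gave no readable size, so the saturated chain, two bonds along from the carbonyl carbon, is the first place in this set where a change has a size that can be read. Against the two compounds that stand at a limit, the size appears only as floors (an at least 22-fold lower number from compound 2 to compound 4 (1.34 log units; beyond the scatter)) and (an at least 22-fold lower number from compound 1 to compound 4 (1.34 log units; beyond the scatter)), both beyond the scatter but open at the far end, and these steps are read against the limit: the limit of > 100000 nM in this assay, at which 2 of the 4 values shown sit.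

Open, from the compounds shown here alone, is whether the drop in the number follows the dimethylamino end or simply the longer chain: a plain pentanoyl ester would separate the two, and a primary amine or a carboxylic acid at the same chain end would test what that end needs. Also open, going by these compounds, is whether the ester link matters, which an amide in its place would show.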